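This account rests on a few compounds, and the source may have more. Where it says the series, first, only, none or still open, it means among the compounds named here.

Measured so far in a functional assay on the whole organism (strain albino) with Mus musculus as the target, with a stated time of 0.5 h; on this read-out lower numbers stand for an effect already at smaller amounts and higher numbers for an effect only at larger amounts of compound:
Compound 1 `O=C(/C=C/c1ccc(Cl)cc1)Nc1nc2ccc(Cl)cc2s1` gives "not determined" (no result reported) as its result
Compound 2 `CC(=O)N1N=C(Nc2nc3ccc(C)cc3s2)CC1c1ccc(O)cc1` gives 54.3 umol/kg as its result
Compound 3 `CC(=O)N1N=C(Nc2nc3ccc([N+](=O)[O-])cc3s2)CC1c1ccc(O)cc1` gives "not determined" (no result reported) as its result

Compound 2 stands alone on these data. Within the data shown here, it carries the only number in the set, while compound 1 and compound 3 yielded none, so it cannot be ranked against either of them.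

Compound 4 `CC(=O)N1N=C(Nc2nc3ccc(C)cc3s2)CC1c1ccccc1` still awaits testing. It departs from compound 2 by hydrogen in place of hydroxy on an aromatic carbon in one place, with hydrogen in place of hydroxy on an aromatic carbon, which turns 4-hydroxyphenyl to phenyl.

Among the measured compounds shown here, no step between measured compounds is available to size such a change, so in this assay no shift beyond the usual scatter is expected, and no firm direction can be given. The expected step is a 1.1-fold higher number from compound 2 to compound 4 (0.04 log units; within the scatter) and no larger than that. With compound 2 at 54.3 umol/kg as the sole anchor, the range has to stay wide. The estimated value for compound 4 is 60 umol/kg within an expected range from 25 umol/kg to 150 umol/kg on present evidence.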

Compound 4, dose for half-maximal effect: 112 umol/kg
Compound 4: the middle estimate sits 1.9-fold (0.27 log units) below what was measured; low and high end bracket the measured number.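

In this assay, among these compounds, the step of a 2.1-fold higher number from compound 2 to compound 4 (0.31 log units; beyond the scatter) gives the first size for any change in this set: losing the hydroxy group from the position para to a large group on the aromatic ring moves the number beyond the scatter, towards larger amounts of compound. The 4-hydroxyphenyl group of compound 2 therefore counts for something here, although the effect remains measurable with the plain phenyl group of compound 4, so the hydroxy group is not required for a result on this read-out. No measurement offered here gives a reason for the shift.

This is a single step at a single place, so it does not show whether the gain is particular to hydroxy. A methoxy group or an amine at the same place could stand with compound 2, with compound 4 or with neither.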